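Aryl-to-thiophene exchange on the hydrazone carbon

A few compounds are considered here, and "the series" means these few. Any claim that something is new, unique, unknown or untested is made for them only; others in the source may bear on it.

compound 1, `CS(=O)(=O)c1ccc(Cc2n[nH]c(=S)n2/N=C/c2ccccc2Cl)cc1`: 36.3%
compound 2, `CS(=O)(=O)c1ccc(Cc2n[nH]c(=S)n2/N=C/c2ccc(F)cc2)cc1`: "not active" (no number reported)
compound 3, `CS(=O)(=O)c1ccc(Cc2n[nH]c(=S)n2/N=C/c2ccccc2F)cc1`: 14%

In a functional assay on HeLa cells (Homo sapiens) for cytotoxicity, read by MTT assay, with a stated time of 48 h, tested at 25 uM (on this read-out higher numbers stand for a stronger effect at the one concentration tested and lower numbers for a weaker effect), compound 3 gives the lower of the two numbers reported; compound 1 sits higher, and compound 2 is reported without a number. Among the compounds with values here, the only measured step, a number 22.3 percentage points lower from compound 1 to compound 3 (beyond the scatter), is a halogen swap on the aromatic ring. Compound 4, `CS(=O)(=O)c1ccc(Cc2n[nH]c(=S)n2/N=C/c2cccs2)cc1`, differs from compound 3 by thiophen-2-yl in place of 2-fluorophenyl on a carbon with a double bond to nitrogen. Within the data shown here, no measured step covers exchange of the whole ring, so the halogen step is only a loose guide; it shows that changes at this ring shift the read-out by modest amounts, and a step of similar size in either direction, or none beyond the scatter, is expected in this assay. The estimate for compound 4 is 18%, with a range of 5% to 40%. This corresponds to an expected step of a number 4 percentage points higher from compound 3 to compound 4 (within the scatter).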

Compound 4, a percentage reported as activity, at one concentration (the size of the read-out at that concentration, not a potency): 33.3%
Compound 4: middle estimate off by 15.3 percentage points, on the low side, within the range that was stated.
By their numbers in this assay, from the lowest: compound 3; then compounds 4 and 1 (each within the scatter of the next).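

In this assay, exchange of the whole ring on the carbon with a double bond to nitrogen can now be read directly: thiophen-2-yl in place of 2-fluorophenyl gives a number 19.3 percentage points higher from compound 3 to compound 4 (beyond the scatter) and thiophen-2-yl in place of 2-chlorophenyl gives a number 3 percentage points lower from compound 1 to compound 4 (within the scatter). Among these compounds, a halogen-bearing phenyl ring is therefore not needed here for a read-out at the level of compound 1. Nothing available explains either step.

Within the data shown here, compound 2 has no number, so no step to it can be read. On these data alone, how an unsubstituted phenyl, a furan-2-yl or a pyridine ring would read at this carbon remains open.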